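A few compounds are considered here, and "the series" means these few. Any claim that something is new, unique, unknown or untested is made for them only; others in the source may bear on it.

Three compounds share a core: compound 1 (`CS(=O)(=O)Oc1c(C(=O)NCc2ccc(F)cc2)nc(Br)c2cccnc12`), compound 2 (`N[C@H]1CC[C@H](Nc2c(C(=O)NCc3ccc(F)cc3)nc(N3CCCCC3)c3cccnc23)CC1`) and compound 3 (`N[C@H]1CC[C@H](Nc2c(C(=O)NCc3ccc(Cl)cc3Cl)nc(Br)c3cccnc23)CC1`). In a functional assay on MCF7 cells (Homo sapiens) for cytotoxicity, read by MTT assay, with a stated time of 72 h (a lower number here means a stronger inhibitor, a higher number a weaker inhibitor), compound 1 gives "not determined" (no result reported). Going by the values given here, in the same test compound 2 gives 5000 nM, the only number available for the series. Among the compounds with values here, compound 3 gives "not determined" (no result reported), so it has no place on the scale, and no measured step connects any of the three compounds.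

Compound 4 (`N[C@H]1CC[C@H](Nc2c(C(=O)NC3CCCCC3)nc(Br)c3cccnc23)CC1`) comes from compound 3 through one change on an amide-type nitrogen: cyclohexyl in place of 2,4-dichlorobenzyl on an amide-type nitrogen. Cyclohexyl stands in place of 2,4-dichlorobenzyl. Without a number for compound 3, the change has no measured starting point in this assay, so no direction can be assigned to it, and no step beyond the scatter is expected. The expectation for compound 4 therefore rests on compound 2 at 5000 nM, although that compound differs from compound 4 in more than one place. Compound 4 is expected to give 4000 nM, with an estimated range from 1000 nM to 16000 nM.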

Compound 4, half-maximal inhibitory concentration: 5200 nM
Compound 4: the middle estimate sits 1.3-fold (0.11 log units) below what was measured, and the stated range covers the measured number.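

In this assay, going by these compounds alone, compound 3 gives "not determined" (no result reported), so no step to compound 4 can be read. The compounds shown leave open how cyclohexyl compares with 2,4-dichlorobenzyl on the amide-type nitrogen. Nothing available bears on the result of compound 4.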